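The source may hold more compounds than are shown below. What is called first, only, known or untested is meant among the compounds shown, and "the series" means these compounds.

Compound 1 `O=C(Nc1ccc(Oc2ccnc3[nH]ccc23)c(F)c1)c1ccc(-c2ccccc2)cn1` is the reference point of this small set. In a functional assay on A549 cells (Homo sapiens) for cytotoxicity, read by MTT assay, with a stated time of 72 h (on this read-out lower numbers stand for stronger inhibition and higher numbers for weaker inhibition), compound 1 gives 1250 nM. Compound 2 `Cc1ccc(-c2ccc(C(=O)Nc3ccc(Oc4ccnc5[nH]ccc45)c(F)c3)nc2)cc1` carries one change relative to compound 1, (methyl in place of hydrogen on an aromatic carbon), and in this assay compound 2 gives 2300 nM; the step is a 1.8-fold higher number from compound 1 to compound 2 (0.26 log units; within the scatter). Compound 3 `O=C(Nc1ccc(Oc2ccnc3[nH]ccc23)c(F)c1)c1cc(-c2ccccc2)ccn1` has the same atoms as compound 1 joined differently, and the difference between the two cores is not broken down here. In this assay compound 3 gives 4950 nM, the highest of the three numbers. Compound 4 `Cc1cccc(-c2ccnc(C(=O)Nc3ccc(Oc4ccnc5[nH]ccc45)c(F)c3)c2)c1` has not yet been measured. It stands to compound 3 as compound 2 stands to compound 1, with methyl in place of hydrogen on an aromatic carbon. The surroundings are not identical: in compound 2 the methyl sits para to a large group, in compound 4 meta to a large group, so this is the same kind of change rather than the same change. Because the earlier step of a 1.8-fold higher number from compound 1 to compound 2 (0.26 log units; within the scatter) stayed within the scatter, the expected step from compound 3 to compound 4 in this assay is also small, a 1.3-fold higher number from compound 3 to compound 4 (0.12 log units; within the scatter). Compound 4 is accordingly estimated at 6500 nM, most likely between 2500 nM and 16000 nM.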

Compound 4, half-maximal inhibitory concentration: 1750 nM
Compound 4: middle estimate off by 3.7-fold (0.57 log units), on the high side; the measured number lies below the stated range.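

Adding the methyl gives a 2.8-fold lower number from compound 3 to compound 4 (0.45 log units; beyond the scatter) in this assay, so on this core the change goes with a stronger result, whereas the earlier step on the core of compound 1 stayed within the scatter. The same change therefore does not carry over unaltered from one core to the other, and a result on one core would have been a poor guide to the other: the same change on two cores in this assay, a 1.8-fold higher number (0.26 log units; within the scatter) from compound 1 to compound 2 and a 2.8-fold lower number (0.45 log units; beyond the scatter) from compound 3 to compound 4, 5.2-fold (0.72 log units) apart, beyond the scatter of two such steps. This does not show that the core alone decides the outcome, for the methyl of compound 4 sits meta to a large group and that of compound 2 sits in a different place, and two pairs of compounds set no rule for the series.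

The compounds shown leave open what the methyl would do if it swapped places between the two cores, which would separate the effect of its place from that of the core. They also leave open how a methoxy group, a chlorine atom or an amine on the same phenyl ring would behave on either core.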